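From Aryltriazole to Morpholinyl Amide: a Cytotoxicity Estimate

The source may report more compounds than this note shows. Statements on the series, on what has been measured and on what is new or still open speak of the compounds shown alone.

Compound 1 `COC(=O)CNC(=O)CCC(=O)Oc1ccc(C[C@H]2C(=O)OC[C@@H]2Cc2ccc(OC)c(OC)c2)cc1OC` gives 179000 nM in an ADME assay on HeLa cells (Homo sapiens) for cytotoxicity, read by MTT assay; on this read-out higher numbers stand for weaker inhibition and lower numbers for stronger inhibition.
Compound 2 `COc1ccc(C[C@H]2COC(=O)[C@@H]2Cc2ccc(OCC(=O)Nc3ccccc3)c(OC)c2)cc1OC` gives >= 600000 nM in this assay, a limit of the assay rather than a number.
Compound 3 `COc1ccc(C[C@H]2COC(=O)[C@@H]2Cc2ccc(OCc3cn(-c4ccc(C)cc4)nn3)c(OC)c2)cc1OC` gives >= 600000 nM in this assay, again a limit of the assay.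

Compound 3 therefore stands at the edge of what this assay reports, and it shares that position with one other compound: the limit of >= 600000 nM in this assay, at which 2 of the 3 values shown sit. Among the values shown only compound 1 carries a number. The step of an at least 3.3-fold higher number from compound 1 to compound 2 (0.52 log units; beyond the scatter) moved the read-out from that number up to the limit, while the step that the two limits leave unreadable from compound 2 to compound 3 runs between two limits and cannot be sized.

Compound 4 `COc1ccc(C[C@H]2COC(=O)[C@@H]2Cc2ccc(OCC(=O)N3CCOCC3)c(OC)c2)cc1OC` is the next compound. Its change from compound 3 is (morpholin-4-yl)carbonyl in place of 1-(4-methylphenyl)-1H-1,2,3-triazol-4-yl on a saturated chain carbon bound to an oxygen on an aromatic ring. Among the measured compounds shown here, the only step at the same place, from compound 2 to compound 3, is unreadable, and the step from compound 1 to compound 2 shows that changing the group on that oxygen can shift the read-out by an at least modest amount toward the limit. Nothing shown points to a move back down, so compound 4 is expected to stay near the limit, with a number no higher from compound 3 to compound 4 (the limit leaves the size open) as the expected step. For compound 4 the estimate is 600000 nM, between 250000 nM and 1500000 nM.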

Compound 4, half-maximal inhibitory concentration: >= 600000 nM
Compound 4: a limit, no number; the forecaster's own chance of this, stated with the estimate: 65%; the middle value lies on the limit itself.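

With the (morpholin-4-yl)carbonyl group, which carries no aromatic ring, compound 4 still sits at the edge of what this assay reports, so aromatic rings in the group on this chain carbon are not needed for a compound to stand there: the limit of >= 600000 nM in this assay, at which 3 of the 4 values shown sit.

Among the compounds shown here, measured against the only value that is a number, the record now shows an at least 3.3-fold higher number from compound 1 to compound 4 (0.52 log units; beyond the scatter), a second change on the oxygen on an aromatic ring that reaches the limit. The steps among the compounds at the limit cannot be read.

From the compounds shown here alone, how far compound 2, compound 3 and compound 4 actually lie beyond the limit stays open. So does whether a carboxylic acid or an amine in place of the (morpholin-4-yl)carbonyl group would bring the read-out down to a number.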